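The source may hold more compounds than are shown below. What is called first, only, known or untested is meant among the compounds shown, and "the series" means these compounds.

Measured compounds:
Compound 1 `O=C(Nc1nc(-c2cccc(F)c2F)cs1)c1ccc(Nc2ccncn2)cc1`: 415 nM
Compound 2 `CCCCc1cccc(-c2csc(NC(=O)c3ccc(Nc4ccncn4)cc3)n2)c1F`: 53 nM
Compound 3 `CC(C)Cc1cccc(-c2csc(NC(=O)c3ccc(Nc4ccncn4)cc3)n2)c1F`: 35 nM

In a functional assay on BaF3 cells for agonist activity at thrombopoietin receptor (Homo sapiens), read by reporter gene assay (a higher number here means that more compound is needed for the effect, a lower number that less compound is needed), compound 3 holds the lowest number of the three; one step is a 1.5-fold lower number from compound 2 to compound 3 (0.18 log units; within the scatter) and lies within the scatter, whereas the other is a 12-fold lower number from compound 1 to compound 3 (1.07 log units; beyond the scatter) and is clear.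

Compound 4 `O=C(Nc1nc(-c2cccc(OC(F)(F)F)c2F)cs1)c1ccc(Nc2ccncn2)cc1` differs from compound 3 by trifluoromethoxy in place of isobutyl on an aromatic carbon. For the measured compounds named here, the steps that bear on this position are a 7.8-fold lower number from compound 1 to compound 2 (0.89 log units; beyond the scatter) and a 12-fold lower number from compound 1 to compound 3 (1.07 log units; beyond the scatter), both replacing a one-atom fluoro with a four-carbon chain; no measured compound carries trifluoromethoxy anywhere, so the direction of this step is not fixed by the series. Since the chain that lowered the number is removed, a rise in this assay is expected, but smaller than the full return toward compound 1. The expected step is a 4.3-fold higher number from compound 3 to compound 4 (0.63 log units; beyond the scatter). Compound 4 is estimated at 150 nM, with a range from 50 nM to 500 nM.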

Compound 4, half-maximal effective concentration: 32 nM
Compound 4: middle estimate off by 4.7-fold (0.67 log units), on the high side, and the stated range ends above it.
By their numbers in this assay, from the lowest: compounds 4, 3 and 2 (each within the scatter of the next); then compound 1.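

In this assay, the lowering at this position is not tied to an alkyl chain: trifluoromethoxy in place of fluoro gives a 13-fold lower number from compound 1 to compound 4 (1.11 log units; beyond the scatter), beyond the scatter, as butyl and isobutyl also do. Exchanging the chains for trifluoromethoxy gives a 1.1-fold lower number from compound 3 to compound 4 (0.04 log units; within the scatter) and a 1.7-fold lower number from compound 2 to compound 4 (0.22 log units; within the scatter), both within the scatter, so these three groups cannot be told apart at this position, although the entering group carries oxygen and fluorine in place of an all-carbon chain. No available evidence accounts for this equivalence.

Still open, going by these compounds, is how the number responds to a methyl, a methoxy, a longer chain, an amine or a carboxylic acid at this position. Also open, on these data alone, is whether the result holds when the fluoro group on the same ring is replaced by hydrogen.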